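A few compounds are considered here, and "the series" means these few. Any claim that something is new, unique, unknown or untested is made for them only; others in the source may bear on it.

- Compound 1 `C/C(=N/NC(=S)Nc1ccccc1F)c1ccccn1`: 0.39 nM
- Compound 2 `C/C(=N/NC(=S)Nc1ccccc1)c1ccccn1`: 0.18 nM
- Compound 3 `C/C(=N/NC(=S)Nc1cccc(I)c1)c1ccccn1`: not yet measured

In a functional assay on MCF7 cells (Homo sapiens) for cytotoxicity, read by MTT assay, with a stated time of 48 h (a lower number here means a stronger inhibitor, a higher number a weaker inhibitor), compound 2 stands lowest of the two measured compounds at 0.18 nM. Compound 3 has iodo in place of hydrogen on an aromatic carbon, meta to a large group: iodo in place of hydrogen on an aromatic carbon. For the measured compounds named here, the one measured step that bears on this is a 2.2-fold lower number from compound 1 to compound 2 (0.34 log units; beyond the scatter), a modest change with hydrogen in place of fluoro. It involves fluoro rather than iodo, so it is only a loose guide. Read in reverse, it suggests a modest rise in the number. The expected change is a 2.2-fold higher number from compound 2 to compound 3 (0.35 log units; beyond the scatter). For compound 3 the estimated value is 0.4 nM, with an expected range of 0.1 nM to 1.5 nM.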

Compound 3, half-maximal inhibitory concentration: 45 nM
Compound 3: the middle estimate sits 110-fold (2.05 log units) below what was measured; the whole stated range lies below it.
By their numbers in this assay, from the lowest: compound 2; then compound 1; then compound 3.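

In this assay, iodo in place of hydrogen on an aromatic carbon, meta to a large group, gives a large loss of potency: a 250-fold higher number from compound 2 to compound 3 (2.40 log units; beyond the scatter). The earlier change, hydrogen in place of fluoro, gave only a modest step, so the new result shows that one heavy atom on this ring can shift the number much further than that pair suggested. No evidence at hand accounts for the size of this rise.

Going by these compounds, it remains open whether the rise follows iodo itself or this place on the ring, and whether chloro or an amine here would behave the same way.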